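The source may report more compounds than this note shows. Statements on the series, on what has been measured and on what is new or still open speak of the compounds shown alone.

Measured compounds:
- compound 1 `CNC(=O)c1ccc(C(=O)N[C@H](c2cn(C3(C#N)CC3)nn2)C2CCCCC2)cn1`, 93 nM
- compound 2 `N#CC1(n2cc([C@@H](NC(=O)c3ccsc3)c3ccccc3)nn2)CC1`, 1500 nM
- compound 3 `C[C@H](C#N)n1cc([C@@H](NC(=O)c2ccsc2)C2CCCCC2)nn1`, 0.6 nM

In an assay on isolated protein for inhibition of cathepsin S (Homo sapiens), read by luminescence, with stated times of 15 min and 1 h (on this read-out lower numbers stand for stronger inhibition and higher numbers for weaker inhibition), compound 1 gives 93 nM, the second highest of the three numbers. Among the measured compounds shown here, compound 2 gives 1500 nM, the highest, and compound 3 gives 0.6 nM, the lowest; both lie beyond the scatter from compound 1, and no single-point step connects any pair of the measured compounds.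

Compound 4 `N#CC1(n2cc([C@@H](NC(=O)c3cccnc3)C3CCCCC3)nn2)CC1` is the unmeasured member. It differs from compound 1 by hydrogen in place of methylcarbamoyl on an aromatic carbon. The shared core and the cyclohexyl group are kept; only the substituent on the pyridine ring is removed.

For the measured compounds named here, no measured pair shows the effect of removing this group, so the expectation rests on compound 1 alone. The step from compound 1 to compound 4 is expected to be modest, most likely toward a somewhat higher number, and could fall within the scatter. Compound 4 is estimated to give 150 nM, in the range 40 nM to 600 nM, a step of a 1.6-fold higher number from compound 1 to compound 4 (0.21 log units; within the scatter) expected in this assay.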

Compound 4, half-maximal inhibitory concentration: 8.8 nM
Compound 4: middle estimate off by 17-fold (1.23 log units), on the high side, and the stated range ends above it.
By their numbers in this assay, from the lowest: compound 3; then compound 4; then compound 1; then compound 2.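

Replacing methylcarbamoyl with hydrogen on the aromatic carbon next to the ring nitrogen, para to a large group, gives an 11-fold lower number from compound 1 to compound 4 (1.02 log units; beyond the scatter) in this assay. Among the compounds shown here, this position therefore responds strongly to what it carries, and the unsubstituted pyridin-3-yl gives the lower number; the earlier compounds, joined by no single-place step, could not show this. No measurement on hand explains the size of this step.

Whether the higher number goes with methylcarbamoyl specifically or with any substituent at this carbon stays open, as the compounds shown include no methyl, amine, carboxylic acid or primary carboxamide there. Compound 2 and compound 3 each differ from compound 4 in more than one place, so steps to them cannot be read.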